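Swapping a Tetrazole for a Pyrazole on a Urea

The source may report more compounds than this note shows. Statements on the series, on what has been measured and on what is new or still open speak of the compounds shown alone.

Compound 1 `Cc1cc(C)c(NC(=O)N(Cc2cccc(-c3nn[nH]n3)c2)C2CCCCCC2)c(C)c1` was tested in an assay on microsomes from intestine for inhibition of acyl-CoA:cholesterol acyltransferase (Oryctolagus cuniculus); on this read-out higher numbers stand for weaker inhibition and lower numbers for stronger inhibition. For compound 1 the outcome is only a limit, > 1000 nM, which is the situation described by the limit of > 1000 nM in this assay, at which 1 of the 3 values shown sits. Two compounds built on a different core already carry a pyrazole: compound 2 `CSc1cc(C)nc(SC)c1NC(=O)N(Cc1ccccc1)Cc1ccc(-c2cc[nH]n2)cc1` gives 55 nM in this assay, and compound 3 `CSc1cc(C)nc(SC)c1NC(=O)N(Cc1ccccc1)Cc1cccc(-c2ccn(C)n2)c1` gives 73 nM, both measured numbers rather than limits. Compound 4 `Cc1cc(C)c(NC(=O)N(Cc2cccc(-c3cc[nH]n3)c2)C2CCCCCC2)c(C)c1` differs from compound 1 in one place: 1H-pyrazol-3-yl in place of 2H-tetrazol-5-yl on an aromatic carbon. Going by the values given here, no measured pair covers this exact change. The step of an at least 3.3-fold lower number from compound 1 to compound 4 (0.52 log units; beyond the scatter) is expected to run toward stronger inhibition, since compound 1 sits at a limit. Compound 4 is therefore estimated at 300 nM, with a plausible range from 50 nM to 2000 nM.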

Compound 4, half-maximal inhibitory concentration: 65 nM
The estimate for compound 4 lay 4.6-fold (0.66 log units) above the measured number; the measured number falls inside the stated range.
By their numbers in this assay, from the lowest: compounds 2, 4 and 3 (each within the scatter of the next). At a limit, above all of these: compound 1.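

In this assay, going by these compounds alone, 1H-pyrazol-3-yl in place of 2H-tetrazol-5-yl gives an at least 15-fold lower number from compound 1 to compound 4 (1.18 log units; beyond the scatter), the first direct reading of this change on an aromatic carbon meta to a large group. The two rings have the same size and the same hydrogen-bond donor count, so the choice of hetero atoms in this ring alone can separate the two results. The full size of the step stays unknown, since compound 1 carries only a limit: the limit of > 1000 nM in this assay, at which 1 of the 4 values shown sits.

The compounds shown leave open whether an imidazole or a carboxylic acid at this position would match the pyrazole.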